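This account rests on a few compounds, and the source may have more. Where it says the series, first, only, none or still open, it means among the compounds named here.

Three compounds measured in a functional assay on DU-145 cells (Homo sapiens) for inhibition, read by trypan blue exclusion, with a stated time of 96 h; on this read-out higher numbers stand for weaker inhibition of growth and lower numbers for stronger inhibition of growth:

Compound 1, `COc1ccc(/C=C(/Sc2ccc(C)cc2)C(=O)c2ccc(Cl)cc2)cc1O`, gives 1000 nM.
Compound 2, `Cc1ccc(S/C(=C/c2ccc(Br)cc2)C(=O)c2ccc(Cl)cc2)cc1`, gives 25000 nM.
Compound 3, `Cc1ccc(S/C(=C/c2c[nH]c3ccccc23)C(=O)c2ccc(Cl)cc2)cc1`, gives 10000 nM.

Compound 3 stands second highest of the three: compound 2 lies above it, a 2.5-fold lower number from compound 2 to compound 3 (0.40 log units; beyond the scatter), and compound 1 lies well below it, a 10-fold higher number from compound 1 to compound 3 (1.00 log units; beyond the scatter). Compound 4, `Cc1ccc(S/C(=C/c2ccc(Cl)cc2)C(=O)c2ccc(Cl)cc2)cc1`, differs from compound 3 in one place: 4-chlorophenyl in place of 1H-indol-3-yl on a double-bonded chain carbon bound to a double-bonded chain carbon. The step that bears on this is a 2.5-fold lower number from compound 2 to compound 3 (0.40 log units; beyond the scatter), in which 1H-indol-3-yl replaced 4-bromophenyl and the number fell modestly; compound 4 reverses that kind of change, with a chlorine rather than a bromine on the entering ring. For comparison, a 25-fold higher number from compound 1 to compound 2 (1.40 log units; beyond the scatter) shows 4-bromophenyl giving the highest number of the three. A modest rise in this assay is therefore expected, a 2.0-fold higher number from compound 3 to compound 4 (0.30 log units; within the scatter). Compound 4 is estimated at 20000 nM, between 8000 nM and 50000 nM.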

Compound 4, concentration for 50% growth inhibition: 10000 nM
Estimate against measurement, compound 4: 2.0-fold (0.30 log units) above; low and high end bracket the measured number.
By their numbers in this assay, from the lowest: compound 1; then compounds 3 and 4 (each within the scatter of the next); then compound 2.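

With 4-chlorophenyl in place of 1H-indol-3-yl at this place, no change at the digits printed from compound 3 to compound 4 (within the scatter), so these two different groups cannot be told apart in this assay. The smaller swap matters more, since chloro in place of bromo on the ring gives a 2.5-fold lower number from compound 2 to compound 4 (0.40 log units; beyond the scatter). Even so, 4-chlorophenyl gives weaker inhibition of growth than 3-hydroxy-4-methoxyphenyl, with a 10-fold higher number from compound 1 to compound 4 (1.00 log units; beyond the scatter).

No measurement shown explains any of these steps. On these data alone, whether an amine or a carboxylic acid on the ring at this place would bring the number closer to that of compound 1 stays open.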